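From 2-methoxyphenyl to 2,4-dimethylphenyl at the assay limit

A few compounds are considered here, and "the series" means these few. Any claim that something is new, unique, unknown or untested is made for them only; others in the source may bear on it.

Measured so far in a functional assay on MCF7 cells (Homo sapiens) for antiproliferative activity, read by MTT assay, with a stated time of 24 h; on this read-out lower numbers stand for stronger inhibition and higher numbers for weaker inhibition
- Compound 1 `CNC(=O)c1ccccc1Oc1nc(Nc2ccc(Br)cc2)ncc1Br` gives > 50000 nM (a limit)
- Compound 2 `CNC(=O)c1ccccc1Oc1nc(Nc2ccccc2OC)ncc1Br` gives > 50000 nM (a limit)

Compound 2 stands only at a limit, not at a number. Compound 3 `CNC(=O)c1ccccc1Oc1nc(Nc2ccc(C)cc2C)ncc1Br` has 2,4-dimethylphenyl in place of 2-methoxyphenyl on a nitrogen on an aromatic ring. For the measured compounds named here, the one measured step bearing on this is a step that the two limits leave unreadable from compound 1 to compound 2 and it offers no size to carry over. The evidence is simply the limit of > 50000 nM in this assay, at which 2 of the 2 values shown sit, and so no direction is expected in this assay for the new step. The expected outcome is a number no higher from compound 2 to compound 3 (the limit leaves the size open) and another limit is the likeliest report. For compound 3 the estimate is 50000 nM (range 20000 nM to 100000 nM) in this assay as an expected value.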

Compound 3, half-maximal inhibitory concentration: 44700 nM
The estimate for compound 3 lay 1.1-fold (0.05 log units) above the measured number, and the stated range covers the measured number.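

In this assay, for the compounds shown here, compound 3 is the first compound here to give a number and not a limit, so 2,4-dimethylphenyl on this nitrogen can be placed on the scale. On these data alone, the data show an at least 1.1-fold lower number from compound 2 to compound 3 (0.04 log units; that floor lies within the scatter) and an at least 1.1-fold lower number from compound 1 to compound 3 (0.04 log units; that floor lies within the scatter) as steps whose true size stays open, while the step between the two earlier compounds cannot be read. This position can therefore carry a group that gives a measured number, though one that still lies close to the limit.

As far as these compounds go, whether an amine or a carboxylic acid on this phenyl ring would give a much lower number remains open.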